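Propenyl replacing ethyl on the shared core

A few compounds are considered here, and "the series" means these few. Any claim that something is new, unique, unknown or untested is made for them only; others in the source may bear on it.

Among the measured compounds shown here, compound 1 `CCc1c(OC)nc2nc(-c3nnc(C)o3)cn2c1C` is the lower of the two numbers measured so far: in a functional assay on the whole organism with Rattus norvegicus as the target (on this read-out lower numbers stand for an effect already at smaller amounts and higher numbers for an effect only at larger amounts of compound), compound 1 gives 2 mg/kg, while compound 2 `CCCc1nnc(-c2cn3c(C)c(CC)c(OC)nc3n2)o1` gives 50 mg/kg. For the measured compounds named here, the single known step, a 25-fold higher number from compound 1 to compound 2 (1.40 log units; beyond the scatter), concerns a different part of the molecule. Compound 3 `C/C=C/c1c(OC)nc2nc(-c3nnc(C)o3)cn2c1C` differs from compound 1 by prop-1-en-1-yl in place of ethyl on an aromatic carbon. Going by the values given here, no measured step touches this position, so the change is expected to stay near the scatter, leaning toward a slightly higher number. For compound 3 the estimate in this assay is 3 mg/kg, within 1 mg/kg to 15 mg/kg, a step of a 1.5-fold higher number from compound 1 to compound 3 (0.18 log units; within the scatter).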

Compound 3, minimum effective dose: > 50 mg/kg
Compound 3 ended at the assay's limit; the forecaster's own chance of this, stated with the estimate: 10%; at least 16-fold (1.22 log units) between middle value and limit.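

Prop-1-en-1-yl in place of ethyl on this aromatic carbon gives an at least 25-fold higher number from compound 1 to compound 3 (1.39 log units; beyond the scatter) in this assay, so this position, untouched by the earlier step, also governs the read-out, and a small change of carbon chain is enough to shift it beyond the scatter. The value of compound 3 is a limit, not a number: the limit of > 50 mg/kg in this assay, at which 1 of the 3 values shown sits.

Still open, on these data alone, is whether the double bond or the extra carbon carries this shift; propyl on this aromatic carbon would separate the two. As far as these compounds go, whether ethyl is the best group here is also open, as methyl or an amine at this place could read either way.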